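Turning a Single Ring Stereocentre in Compound 2

The source may hold more compounds than are shown below. What is called first, only, known or untested is meant among the compounds shown, and "the series" means these compounds.

Of the compounds shown here, two have so far been tested in an assay on HEK293-A cells for agonist activity at probable G-protein coupled receptor 34 (Mus musculus), with a stated time of 1.5 h; a lower number here means a smaller maximal response, a higher number a larger maximal response. Compound 1 `CCCCCCCCCCCOc1ccccc1CCC(=O)OCc1ccc(OP(=O)(O)OC[C@H](N)C(=O)O)cc1` is reported as "not active" (no number reported), with no number attached. For the measured compounds named here, compound 2 `CCCCCCCC/C=C\CCCCCCCC(=O)O[C@@H]1C=CCO[C@@H]1COP(=O)(O)OC[C@H](N)C(=O)O` gives 3.8%, a small maximal response, and it is the only compound with a number to stand on here; compound 1 is the one further entry, carrying no value. Compound 3 `CCCCCCCC/C=C\CCCCCCCC(=O)O[C@H]1C=CCO[C@@H]1COP(=O)(O)OC[C@H](N)C(=O)O` has not been measured yet. It differs from compound 2 in a single way: the two compounds have the same atoms and bonds; at least one stereo element is drawn with a configuration in one of them and without one in the other: 1 of 5 stereo elements differ; a stereocentre at a saturated ring carbon is drawn R in compound 2 and S in compound 3. Every atom and bond stays in place; only the drawn arrangement at one saturated ring carbon is turned around. Going by the values given here, no pair of measured compounds that differ in one place is available to show how large such a change can be in this assay. With compound 2 already giving a small response, compound 3 is expected to sit close to it, with a step of a number 2.2 percentage points higher from compound 2 to compound 3 (within the scatter) that stays within the usual scatter rather than moving clearly in either direction. Compound 3 is thus estimated at 6%, somewhere between 0% and 25%, with a fair chance that it is simply reported as not active.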

Compound 3, largest response reached (Emax), in percent of the reference or control that the assay uses: "not active" (no number reported)
Compound 3 has no reported number here; there is nothing to compare the estimate with.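

For the compounds shown here, compound 3 is reported as not active with no number, so no step from compound 2 to compound 3 can be read in this assay. The compounds shown leave open how far turning this single ring stereocentre can shift the maximal response. One point about the drawn structures of this pair still stands: the fact that one of compounds 2 and 3 is drawn with a defined configuration and the other without, at the place where they differ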